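The source may report more compounds than this note shows. Statements on the series, on what has been measured and on what is new or still open speak of the compounds shown alone.

Three compounds have been measured in an assay on isolated protein for displacement of a labelled ligand from secreted frizzled-related protein 1 (Homo sapiens), read by fluorescence polarization, with a stated time of 30 min; a lower number here means a stronger inhibitor, a higher number a weaker inhibitor:

Compound 1 `O=C(c1cccc(Cl)c1)N1CCC(NS(=O)(=O)c2cc(S(=O)(=O)c3ccccc3)ccc2C(F)(F)F)CC1`: 300 nM
Compound 2 `N#Cc1cccc(S(=O)(=O)N2CCC(NS(=O)(=O)c3cc(S(=O)(=O)c4ccccc4)ccc3C(F)(F)F)CC2)c1`: 90 nM
Compound 3 `CC(C)(C)OC(=O)N1CC[C@H](C(=O)N2CCC(NS(=O)(=O)c3cc(S(=O)(=O)c4ccccc4)ccc3C(F)(F)F)CC2)C1`: 70 nM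

Compound 1 gives the highest number of the three, and both other compounds sit beyond the scatter from it: a 3.3-fold lower number from compound 1 to compound 2 (0.52 log units; beyond the scatter) and a 4.3-fold lower number from compound 1 to compound 3 (0.63 log units; beyond the scatter). Compound 4 `O=C(CC1CCNCC1)N1CCC(NS(=O)(=O)c2cc(S(=O)(=O)c3ccccc3)ccc2C(F)(F)F)CC1` has not yet been measured. It differs from compound 1 in one place: (piperidin-4-yl)methyl in place of 3-chlorophenyl on a carbonyl carbon.

The step that bears most on this change is a 4.3-fold lower number from compound 1 to compound 3 (0.63 log units; beyond the scatter), where the same 3-chlorophenyl on the carbonyl carbon also gave way to a six-membered non-aromatic ring with 1 hetero atom, there as 1-(tert-butoxycarbonyl)pyrrolidin-3-yl. The step of a 3.3-fold lower number from compound 1 to compound 2 (0.52 log units; beyond the scatter) alters a different part of the shared core, yet it too shows that compound 1 is easy to improve on. Compound 4 carries a hydrogen-bond donor that neither compound 1 nor compound 3 has, so the two cases are not alike, and the expectation rests on one step only. A modest lowering is therefore expected, about a 2.0-fold lower number from compound 1 to compound 4 (0.30 log units; within the scatter). Compound 4 is expected to give 150 nM in this assay, within a range from 50 nM to 600 nM.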

Compound 4, half-maximal inhibitory concentration: 100 nM
Compound 4: middle estimate off by 1.5-fold (0.18 log units), on the high side, within the range that was stated.
By their numbers in this assay, from the lowest: compounds 3, 2 and 4 (each within the scatter of the next); then compound 1.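

In this assay, the carbonyl carbon accepts (piperidin-4-yl)methyl in place of 3-chlorophenyl with a real gain (a 3.0-fold lower number from compound 1 to compound 4 (0.48 log units; beyond the scatter)), so a non-aromatic ring carrying a hydrogen-bond donor works here, which compound 3 could not show. This group cannot be told apart from the 1-(tert-butoxycarbonyl)pyrrolidin-3-yl group (a 1.4-fold higher number from compound 3 to compound 4 (0.15 log units; within the scatter)), nor from the (3-cyanophenyl)sulfonyl change on the ring nitrogen (a 1.1-fold higher number from compound 2 to compound 4 (0.05 log units; within the scatter)), so quite different groups on this nitrogen end up level. Nothing measured here explains the gain.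

The compounds shown leave open whether the piperidine nitrogen itself counts, which a cyclohexylmethyl group, with carbon in its place, would test. From the compounds shown here alone, the length of the chain carrying the ring is equally open, and a 2-(piperidin-4-yl)ethyl group would probe it.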